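This account rests on a few compounds, and the source may have more. Where it says the series, first, only, none or still open, it means among the compounds named here.

Compound 3 `CN1CCN(c2nc3ccccc3n2-c2ccccc2)CC1` is one of three compounds tested in a functional assay on ileum for inhibition of histamine H1 receptor (Cavia porcellus) (a lower number here means a stronger inhibitor, a higher number a weaker inhibitor), where compound 3 gives 760 nM. Among the three numbers it stands second highest. Its nearest neighbour is compound 2 `COCCCn1c(N2CCN(C)CC2)nc2ccccc21`, which gives 860 nM; the step of a 1.1-fold lower number from compound 2 to compound 3 (0.05 log units; within the scatter) lies within the usual scatter. Furthest away is compound 1 `CN1CCN(c2nc3ccccc3n2CCO)CC1`, which gives 410 nM; the step of a 1.9-fold higher number from compound 1 to compound 3 (0.27 log units; within the scatter) also stays within the scatter. For the measured compounds named here, the one step that reaches beyond the scatter is a 2.1-fold higher number from compound 1 to compound 2 (0.32 log units; beyond the scatter).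

Compound 4 `CCSCCCn1c(N2CCN(C)CC2)nc2ccccc21` has not been measured yet. It differs from compound 3 in one place: 3-(ethylsulfanyl)propyl in place of phenyl on an aromatic nitrogen. Going by the values given here, two measured steps bear on this change, since both replace a chain on the same aromatic nitrogen with phenyl: a 1.9-fold higher number from compound 1 to compound 3 (0.27 log units; within the scatter) and a 1.1-fold lower number from compound 2 to compound 3 (0.05 log units; within the scatter), neither of them beyond the scatter. Going the other way, from phenyl back to a chain, a step of about the same small size is therefore expected, if any: a 1.1-fold higher number from compound 3 to compound 4 (0.02 log units; within the scatter). On this basis compound 4 is estimated at 800 nM, with a range from 350 nM to 1800 nM.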

Compound 4, half-maximal inhibitory concentration: 530 nM
Estimate against measurement, compound 4: 1.5-fold (0.18 log units) above; the measured number falls inside the stated range.
By their numbers in this assay, from the lowest: compounds 1, 4, 3 and 2 (each within the scatter of the next, the first and the last beyond it).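

On this aromatic nitrogen, a chain carrying sulfur can take the place of a ring in this assay without a step beyond the scatter: a 1.4-fold lower number from compound 3 to compound 4 (0.16 log units; within the scatter) is the swap of phenyl for 3-(ethylsulfanyl)propyl, two groups with the same count of heavy atoms. The comparisons with the other chains, a 1.6-fold lower number from compound 2 to compound 4 (0.21 log units; within the scatter) and a 1.3-fold higher number from compound 1 to compound 4 (0.11 log units; within the scatter), also stay within the scatter, so compound 4 cannot be told apart from any earlier compound, even though compound 1 and compound 2 can be told apart from each other. Nothing measured here accounts for how close these numbers lie.

Still open, going by these compounds, is whether a chain ending in an amine or a carboxylic acid on this nitrogen would stay as close. The same question holds for a much longer chain, and every compound shown keeps the 4-methylpiperazin-1-yl group, so a different group at that place also remains untested here.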